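Working notes: cytotoxicity across compounds 1 to 4

A few compounds are considered here, and "the series" means these few. Any claim that something is new, unique, unknown or untested is made for them only; others in the source may bear on it.

Measured so far, in an ADME assay on HEL cells (Homo sapiens) for cytotoxicity; on this read-out higher numbers stand for lower toxicity in this test and lower numbers for higher toxicity in this test:
compound 1 `CCN(CC)CN1C(=O)/C(=N/NC(=S)Nc2ccccc2)c2ccccc21` — a limit of the assay, > 100000 nM
compound 2 `CCN(CC)CN1C(=O)/C(=N/NC(=S)Nc2ccc(C)cc2)c2ccccc21` — 100000 nM
compound 3 `CCN(CC)CN1C(=O)/C(=N/NC(=S)Nc2ccc(C)cc2)c2cc(Cl)ccc21` — 100000 nM

Compound 2 sits at the same reading as compound 3 at the digits given, with no change at the digits printed from compound 2 to compound 3 (within the scatter). For compound 1 only a limit is known, and that one value sits at the limit of > 100000 nM in this assay, at which 1 of the 3 values shown sits. The step of a number no higher from compound 1 to compound 2 (the limit leaves the size open) therefore has no readable size, and compound 2 cannot be placed above or below compound 1 on the numbers shown; among the numbers that are not limits, compound 2 and compound 3 are level.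

The step to compound 4 `CCN(CC)CN1C(=O)/C(=N/NC(=S)Nc2ccc(OC)cc2)c2ccccc21` is methoxy in place of methyl on an aromatic carbon. For the measured compounds named here, two measured steps bear on it, both substitutions on an aromatic carbon of the shared core: a number no higher from compound 1 to compound 2 (the limit leaves the size open), which the limit leaves open, and no change at the digits printed from compound 2 to compound 3 (within the scatter), which stayed within the scatter. Neither gives any sign of a change in this assay from a small group on a ring, so no step beyond the scatter is expected, in either direction, and the reading may again fall at the ceiling of the assay rather than as a number.

Compound 4 is expected to give 100000 nM in this assay, within 50000 nM to 200000 nM. The estimated step is no change at the digits printed from compound 2 to compound 4 (within the scatter).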

Compound 4, minimum cytotoxic concentration: 100000 nM
For compound 4 middle estimate and measured number coincide at the digits printed; measured number inside the range.
By their numbers in this assay, from the lowest: compounds 2, 3 and 4 (each within the scatter of the next).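

In this assay, for the exchange at the aromatic carbon para to a large group, 4-methylphenyl to 4-methoxyphenyl, there is no change at the digits printed from compound 2 to compound 4 (within the scatter). For the compounds shown here, this is the first readable step at this position between two substituents, and it shows that adding an oxygen and a hydrogen-bond acceptor there leaves the printed reading unmoved. Compound 1 stands at a limit of the assay. There is a number no higher from compound 1 to compound 4 (the limit leaves the size open), and like every step from that limit it cannot be read, so the comparison with the unsubstituted ring remains closed: the limit of > 100000 nM in this assay, at which 1 of the 4 values shown sits.

On these data alone, whether the reading at this position would hold with an amine, a carboxylic acid or a longer chain such as butoxy in place of methoxy remains open. Compounds 2, 3 and 4 also share one printed reading, so these compounds do not yet identify any change on the shared core that moves this assay to a clearly different number.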